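The source may report more compounds than this note shows. Statements on the series, on what has been measured and on what is new or still open speak of the compounds shown alone.

Compound 1 `CCCCCCCCCCc1ccc(-c2noc(C3CNC3)n2)cc1` stands highest of the three compounds measured in an assay on HeLa cells for inhibition of sphingosine-1-phosphate transporter SPNS2 (Mus musculus), read by LC-MS, tested at 2 uM (on this read-out higher numbers stand for more inhibition at the one concentration tested (going by the name of the read-out) and lower numbers for less inhibition), where compound 1 gives 65%. Its two open-chain relatives fall well behind it: compound 2 `CCCCCCCCCCc1ccc(-c2noc(C(Cl)CCN)n2)cc1` gives 5% and compound 3 `CCCCCCCCCCc1ccc(-c2noc(CC(CN)OC(C)=O)n2)cc1` gives 0%, so that the step from compound 1 is a number 60 percentage points lower from compound 1 to compound 2 (beyond the scatter) and a number 65 percentage points lower from compound 1 to compound 3 (beyond the scatter), while between the two open-chain compounds it is only a number 5 percentage points lower from compound 2 to compound 3 (within the scatter).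

Compound 4 `CCCCCCCCCCc1ccc(-c2noc([C@@H](N)CCCN)n2)cc1` takes the same kind of step away from compound 1: 1,4-diaminobutyl in place of azetidin-3-yl on an aromatic carbon. The two measured steps that bear on it, opening the four-membered ring into a chain, were both large losses. Compound 4, however, brings 1,4-diaminobutyl with two hydrogen-bond donors and a defined stereocentre, which neither compound 2 nor compound 3 carries, so the precedent covers it only in part. A drop is therefore expected, but a smaller one than the measured steps suggest, and the expected change is a number 30 percentage points lower from compound 1 to compound 4 (beyond the scatter). Compound 4 is estimated at 35%, within a range from 5% to 75%.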

Compound 4, a percentage reported as inhibition, at one concentration (the size of the read-out at that concentration, not a potency): 40%
Beside the measured number, compound 4's estimate is 5 percentage points below it; the measured number falls inside the stated range.
By their numbers in this assay, from the lowest: compounds 3 and 2 (each within the scatter of the next); then compound 4; then compound 1.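

In this assay, opening the four-membered ring at this position does not by itself abolish inhibition: 1,4-diaminobutyl in place of azetidin-3-yl gives only a number 25 percentage points lower from compound 1 to compound 4 (beyond the scatter). The identity of the open chain matters a great deal, since the data show a number 40 percentage points higher from compound 3 to compound 4 (beyond the scatter) and a number 35 percentage points higher from compound 2 to compound 4 (beyond the scatter), although no open-chain group among these compounds reaches compound 1. Nothing at hand explains these differences.

The compounds shown do not separate the contributions of the second amine and the defined stereocentre of compound 4. From the compounds shown here alone, a 4-aminobutyl chain carrying a single amine, the opposite stereoisomer of 1,4-diaminobutyl, or a pyrrolidin-3-yl ring in place of azetidin-3-yl would each address a question that remains open here.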